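The compounds below may be only part of what the source reports. "The series", "measured", "known", "first", "only" and "open" are said of these compounds alone.

Measured so far in an assay on HeLa cells for binding affinity to 5-hydroxytryptamine receptor 6 (Homo sapiens); a higher number here means a weaker inhibitor, a lower number a stronger inhibitor:
compound 1 `NCCn1cc(S(=O)(=O)c2ccccc2)c2ccc(Cl)cc21` gives 141 nM
compound 2 `COc1ccc2c(S(=O)(=O)c3ccccc3)cn(CCN(C)C)c2c1` gives 23 nM
compound 3 `CN(C)CCn1cc(S(=O)(=O)c2ccccc2)c2ccc(F)cc21` gives 46 nM

Compound 3 stands near compound 2, the gap between them within the scatter, while the gap to compound 1 lies beyond it; compound 1 has the highest number of the three. Among the measured compounds shown here, the only single-point step measured is a 2.0-fold higher number from compound 2 to compound 3 (0.30 log units; within the scatter). Compound 4 `CN(C)CCn1cc(S(=O)(=O)c2ccccc2)c2ccc(Cl)cc21` differs from compound 3 by chloro in place of fluoro on an aromatic carbon. For the measured compounds named here, no measured step exchanges fluoro for chloro; compound 1 carries chloro but also a different side chain, so its value alone cannot settle the halogen effect. A step in this assay of a 1.2-fold higher number from compound 3 to compound 4 (0.08 log units; within the scatter) is therefore expected, within the scatter. For compound 4 the estimate is 55 nM, with a range from 25 nM to 120 nM.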

Compound 4, inhibition constant: 42 nM
For compound 4 the middle estimate is 1.3-fold (0.12 log units) above the measured one; low and high end bracket the measured number.
By their numbers in this assay, from the lowest: compounds 2, 4 and 3 (each within the scatter of the next); then compound 1.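

In this assay, among the compounds shown here, the first direct halogen exchange on this aromatic carbon separates nothing: chloro in place of fluoro (a 1.1-fold lower number from compound 3 to compound 4 (0.04 log units; within the scatter)) and chloro in place of methoxy (a 1.8-fold higher number from compound 2 to compound 4 (0.26 log units; within the scatter)) both stay within the scatter. With chloro held fixed, the side chain can now be read alone, and dimethylamino in place of amino gives a step beyond the scatter (a 3.4-fold lower number from compound 1 to compound 4 (0.53 log units; beyond the scatter)). No evidence bears on the cause of these results.

Still open, on these data alone, is whether a nitrile or trifluoromethyl on this carbon would stay within the same range. The side-chain step rests on one chloro pair, leaving a longer chain or a cyclic amine untested here.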